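Adding Two Fluorines to the Terminal Phenyl Ring

The compounds below may be only part of what the source reports. "The series", "measured", "known", "first", "only" and "open" are said of these compounds alone.

Of the compounds shown here, two sharing one core have been measured in a functional assay on MKN-45 cells (Homo sapiens) for cytotoxicity, read by MTT assay, with a stated time of 72 h; a higher number here means a weaker inhibitor, a lower number a stronger inhibitor. Compound 1 `COc1cc2c(Oc3ccc(NC(=O)N/N=C/c4cccs4)cc3F)ccnc2cc1OCCCN1CCCCC1` gives 740 nM. Within the data shown here, compound 2 `COc1cc2c(Oc3ccc(/C=N/NC(=O)Nc4ccccc4)cc3F)ccnc2cc1OCCCN1CCCCC1` gives 180 nM, the lower of the two numbers, and the single measured step, a 4.1-fold lower number from compound 1 to compound 2 (0.61 log units; beyond the scatter), separates them. Compound 3 `COc1cc2c(Oc3ccc(/C=N/NC(=O)Nc4ccc(F)c(F)c4)cc3F)ccnc2cc1OCCCN1CCCCC1` is the next compound to be measured. It differs from compound 2 by 3,4-difluorophenyl in place of phenyl on an amide-type nitrogen. Among the measured compounds shown here, no measured step bears on this kind of change: the one known step swaps a whole group at a different place and leaves the phenyl ring untouched, so it says nothing about fluorine atoms on that ring. With no guidance from the numbers, the expected change is none beyond the scatter, and compound 3 is estimated at 150 nM in this assay, within a range of 50 nM to 450 nM. That estimate corresponds to an expected step of a 1.2-fold lower number from compound 2 to compound 3 (0.08 log units; within the scatter).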

Compound 3, half-maximal inhibitory concentration: 320 nM
For compound 3 the middle estimate is 2.1-fold (0.33 log units) below the measured one; measured number inside the range.
By their numbers in this assay, from the lowest: compounds 2 and 3 (each within the scatter of the next); then compound 1.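

In this assay, 3,4-difluorophenyl in place of phenyl on the amide-type nitrogen gives a 1.8-fold higher number from compound 2 to compound 3 (0.25 log units; within the scatter), so the two fluorines leave compound 3 and compound 2 within the usual scatter of each other. Among these compounds, this is the first measured change to the ring at this position, and it shows that this ring can carry these two fluorines with no difference that the assay can separate from repeat-to-repeat variation. No measurement is available that would explain this result. On these data alone, it remains open whether a single fluorine would read the same way, or whether a chlorine, a methoxy group, an amine or a carboxylic acid on this ring would shift the number beyond the scatter. Replacing the phenyl ring with a saturated ring such as cyclohexyl is also an open case.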